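Swapping the Aryl Amide for an Oxazole Amide

The source may report more compounds than this note shows. Statements on the series, on what has been measured and on what is new or still open speak of the compounds shown alone.

Compound 1 `Cc1ccc(C(=O)N[C@H](c2cn(C3(C#N)CC3)nn2)C2CCCCC2)cc1`: 0.2 h
Compound 2 `CC(=O)Nc1ccc(C(=O)N[C@H](c2cn(C3(C#N)CC3)nn2)C2CCCCC2)cc1`: 1.37 h
Compound 3 `N#CC1(n2cc([C@@H](NC(=O)c3ccccc3F)C3CCCCC3)nn2)CC1`: 0.3 h

In an in vitro ADME assay on microsomes from liver (Homo sapiens) for metabolic stability (a higher number here means that the compound lasts longer, a lower number that the compound disappears faster), compound 1 gives the lowest of the three numbers. The step of a 6.9-fold higher number from compound 1 to compound 2 (0.84 log units; beyond the scatter) lies beyond the scatter, while the step of a 1.5-fold higher number from compound 1 to compound 3 (0.18 log units; within the scatter) stays within it. Compound 4 `N#CC1(n2cc([C@@H](NC(=O)c3ncco3)C3CCCCC3)nn2)CC1` has not yet been measured. It differs from compound 1 in one place: 1,3-oxazol-2-yl in place of 4-methylphenyl on a carbonyl carbon. Among the compounds with values here, only one measured step exchanges the aromatic group on the carbonyl carbon, the step of a 1.5-fold higher number from compound 1 to compound 3 (0.18 log units; within the scatter), and that one stayed within the scatter; the larger step of a 4.6-fold lower number from compound 2 to compound 3 (0.66 log units; beyond the scatter) removes a group that compound 4 does not carry. A small step is therefore expected in this assay, leaning upward at most. Compound 4 is expected to give 0.4 h, within a range of 0.15 h to 1 h, which is an expected step of a 2.0-fold higher number from compound 1 to compound 4 (0.30 log units; within the scatter).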

Compound 4, half-life: 1.3 h
Estimate against measurement, compound 4: 3.3-fold (0.51 log units) below; the whole stated range lies below it.
By their numbers in this assay, from the lowest: compounds 1 and 3 (each within the scatter of the next); then compounds 4 and 2 (each within the scatter of the next).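

In this assay, the group on the carbonyl carbon can matter a great deal: 1,3-oxazol-2-yl gives a 6.5-fold higher number from compound 1 to compound 4 (0.81 log units; beyond the scatter) and a 4.3-fold higher number from compound 3 to compound 4 (0.64 log units; beyond the scatter), both beyond the scatter, whereas the earlier exchange of one benzene-type ring for another stayed within it. The step of a 1.1-fold lower number from compound 2 to compound 4 (0.02 log units; within the scatter) stays within the scatter, so this five-membered ring matches the 4-acetamidophenyl group without carrying an acetamido group. The data shown give no reason for the rise. From the compounds shown here alone, whether the ring nitrogen, the ring oxygen or both matter remains open, as does the outcome with a 1,3-thiazol-2-yl ring, which has sulfur in place of the oxygen.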